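The source may report more compounds than this note shows. Statements on the series, on what has been measured and on what is new or still open speak of the compounds shown alone.

Compound 1 `c1ccc(-c2ccc(-c3ccc(-c4nc5ccccc5[nH]4)cc3)cc2)cc1`: 32100 nM
Compound 2 `COc1cc(-c2ccc(-c3ccc(-c4nc5cc(C)ccc5[nH]4)cc3)cc2)cc(OC)c1OC`: 190 nM
Compound 3 `COc1ccc(-c2ccc(-c3ccc(-c4nc5ccccc5[nH]4)cc3)cc2)cc1OC`: 21600 nM

These values come from a functional assay on A2780 cells (Homo sapiens) for inhibition, read by sulforhodamine B assay; on this read-out lower numbers stand for stronger inhibition of growth and higher numbers for weaker inhibition of growth. Compound 3, at 21600 nM, cannot be told apart from compound 1 and stands well above compound 2. Compound 4 `COc1cc(-c2ccc(-c3ccc(-c4nc5ccccc5[nH]4)cc3)cc2)cc(OC)c1OC` has methoxy in place of hydrogen on an aromatic carbon of compound 3: methoxy in place of hydrogen on an aromatic carbon. For the measured compounds named here, the one measured step, a 1.5-fold lower number from compound 1 to compound 3 (0.17 log units; within the scatter), lies within the scatter, so taken alone it points to no change. However, compound 4 shares its methoxy pattern with compound 2, which adds a methyl on the shared core and gives 190 nM. What that methyl contributes is unmeasured. A large drop beyond the scatter is therefore expected, a 54-fold lower number from compound 3 to compound 4 (1.73 log units; beyond the scatter). For compound 4 the estimated value is 400 nM, with an expected range of 90 nM to 3000 nM.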

Compound 4, concentration for 50% growth inhibition: 9210 nM
Compound 4: middle estimate off by 23-fold (1.36 log units), on the low side; the whole stated range lies below it.
By their numbers in this assay, from the lowest: compound 2; then compound 4; then compounds 3 and 1 (each within the scatter of the next).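

In this assay, methoxy in place of hydrogen at this position gives a 2.3-fold lower number from compound 3 to compound 4 (0.37 log units; beyond the scatter), a modest but real gain. Hydrogen in place of methyl on an aromatic carbon gives a 48-fold higher number from compound 2 to compound 4 (1.69 log units; beyond the scatter), so with this methoxy pattern in place, that single methyl on the shared core counts for far more than the added methoxy. Nothing available explains either step.

From the compounds shown here alone, whether the methyl would give as large a change on compound 1 or compound 3 stays open. So does how an amine or a hydroxyl would compare with methoxy at this position.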